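From 4-hydroxycyclohexyl to morpholin-4-yl on the amide

The compounds below may be only part of what the source reports. "The series", "measured", "known", "first", "only" and "open" are said of these compounds alone.

In an ADME assay on MRC5 cells (Homo sapiens) for inhibition, with a stated time of 72 h (a lower number here means that less compound is needed, a higher number that more compound is needed for the effect), compound 1 (`CO[C@H]1CC[C@H](NC(=O)c2n[nH]cc2NC(=O)c2ncoc2-c2ccccc2)CC1`) gives 28000 nM and compound 2 (`COc1cccc(OC)c1C(=O)Nc1c[nH]nc1C(=O)N[C@H]1CC[C@H](O)CC1`) gives 34000 nM as its value, and these two lie within the usual scatter of each other. Compound 3 (`COc1cccc(OC)c1C(=O)Nc1c[nH]nc1C(=O)NN1CCOCC1`) has morpholin-4-yl in place of 4-hydroxycyclohexyl on an amide-type nitrogen. For the measured compounds named here, no measured pair shows this change, so the only guide is compound 2 at 34000 nM and no shift beyond the scatter is expected in this assay for now. The expected step (a 1.1-fold higher number from compound 2 to compound 3 (0.05 log units; within the scatter)) is small. For compound 3 the estimated value is 38000 nM (expected range 15000 nM to 85000 nM).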

Compound 3, half-maximal effective concentration: > 50000 nM
Compound 3 was reported as a limit (the forecaster's own chance of this, stated with the estimate: 30%); middle value at least 1.3-fold (0.11 log units) away from the limit.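

In this assay the value of compound 3 is a limit, not a number: the limit of > 50000 nM in this assay, at which 1 of the 3 values shown sits. The change gives an at least 1.4-fold higher number from compound 2 to compound 3 (0.16 log units; that floor lies within the scatter), so morpholin-4-yl on this amide-type nitrogen shows no sign of a lower number than 4-hydroxycyclohexyl, although this floor does not clear the scatter. For the compounds shown here, it is the first single change read at this place, since compound 1 and compound 2 differ in more than one place.

From the compounds shown here alone, the true size of the step stays open. So does the reading for a piperidin-1-yl group or a simple dimethylamino group on the same nitrogen.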